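Moving the hydroxyl on a pyridine-linked phenyl ring

The source may report more compounds than this note shows. Statements on the series, on what has been measured and on what is new or still open speak of the compounds shown alone.

Measured so far:
compound 1, `Oc1cccc(-c2cc(-c3cccc(Cl)c3)nc(-c3ccco3)c2)c1`: 2020 nM
compound 2, `Oc1ccc(-c2cc(-c3ccccc3)nc(-c3cccc(Cl)c3)c2)cc1`: 5360 nM

In a functional assay on DU-145 cells (Homo sapiens) for cytotoxicity, read by CCK-8 assay and cell counting, with a stated time of 2 days (a lower number here means a stronger inhibitor, a higher number a weaker inhibitor), compound 2 gives 5360 nM, the highest of the two numbers recorded; its nearest neighbour is compound 1, which in this assay gives 2020 nM, a gap beyond the scatter. Within the data shown here, compound 1 and compound 2 differ in more than one place, so no single step between them is defined; their two values simply show that compound 1 sits lower.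

Compound 3, `Oc1cccc(-c2cc(-c3ccccc3)nc(-c3cccc(Cl)c3)c2)c1`, is not yet measured. It differs from compound 2 by 3-hydroxyphenyl in place of 4-hydroxyphenyl on an aromatic carbon, so that compound 3 carries the hydroxyl in the same arrangement as compound 1 while keeping the phenyl and 3-chlorophenyl groups of compound 2. Compound 1 with 2020 nM is the only hint available, and it is an imperfect one. A modest downward step is expected, a 1.8-fold lower number from compound 2 to compound 3 (0.25 log units; within the scatter), though it may fall within the scatter. Compound 3 is expected to give about 3000 nM, somewhere between 1200 nM and 8000 nM.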

Compound 3, half-maximal inhibitory concentration: 2750 nM
Compound 3: middle estimate off by 1.1-fold (0.04 log units), on the high side; measured number inside the range.
By their numbers in this assay, from the lowest: compounds 1, 3 and 2 (each within the scatter of the next, the first and the last beyond it).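

In this assay the shift from 4-hydroxyphenyl to 3-hydroxyphenyl, at the place opposite the ring nitrogen, gives a 1.9-fold lower number from compound 2 to compound 3 (0.29 log units; within the scatter) and so does not separate these two arrangements of the hydroxyl. Among these compounds, compound 3 also provides the first single-place comparison with compound 1, and phenyl in place of furan-2-yl gives a 1.4-fold higher number from compound 1 to compound 3 (0.13 log units; within the scatter), so these two groups are not separated here either. No evidence on the cause of either step is available.

The compounds shown leave open whether replacing the hydroxyl with an amine, a methoxy group or a carboxylic acid would move the number beyond the scatter. On these data alone, it is also open whether a saturated ring such as piperidine or morpholine, in place of phenyl or furan-2-yl, would do so.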